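This account rests on a few compounds, and the source may have more. Where it says the series, first, only, none or still open, it means among the compounds named here.

Working notes on the series in a functional assay on MCF7 cells (Homo sapiens) for inhibition, read by MTT assay, with a stated time of 72 h; a higher number here means a weaker inhibitor, a lower number a stronger inhibitor.

Compound 1 `COc1cc(OC)c(OC)cc1/C=C/C(=O)c1ccc(O)cc1` carries a hydroxy on the aromatic carbon of the ring bearing the carbonyl, and in this assay compound 1 gives 182000 nM. Compound 2 `COc1cc(OC)c(OC)cc1/C=C/C(=O)c1ccc([N+](=O)[O-])cc1` replaces that hydroxy with nitro. In this assay compound 2 returns only a limit, > 150000 nM, and no number. The step that the limit leaves unreadable from compound 1 to compound 2 is therefore not readable in size, because the limit of > 150000 nM in this assay, at which 1 of the 2 values shown sits, is where one of the two measured values sits. Going by these compounds, compound 2 thus stands at the weak end of what the assay can report, and its true value is unknown beyond that bound.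

Compound 3 `COc1cc(OC)c(OC)cc1/C=C/C(=O)c1ccc(-c2c[nH]cn2)cc1` is the next member: 1H-imidazol-4-yl in place of nitro on an aromatic carbon. Going by the values given here, no measured step addresses an aromatic heterocycle at this position, and the only step that exists, from compound 1 to compound 2, gives no readable size. Without a usable reference step, compound 3 is expected to remain in the weak range, with the step of a number no higher from compound 2 to compound 3 (the limit leaves the size open) estimated as a guess rather than a projection. In this assay compound 3 is estimated at 150000 nM, within 30000 nM to 500000 nM.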

Compound 3, half-maximal inhibitory concentration: > 150000 nM
Compound 3: only a limit was reported; the forecaster's own chance of this, stated with the estimate: 40%; the middle value sits exactly at the limit.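

In this assay compound 3 gives only a limit, > 150000 nM. The steps from compound 1 to compound 3 and from compound 2 to compound 3 cannot be read in size, because the values stop at one bound: the limit of > 150000 nM in this assay, at which 2 of the 3 values shown sit.

The compounds shown leave open where the true values of compound 2 and compound 3 lie, and whether nitro and 1H-imidazol-4-yl differ at all.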